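A fluorine added to the aryl ring of compound 1

The source may report more compounds than this note shows. Statements on the series, on what has been measured and on what is new or still open speak of the compounds shown alone.

Among the compounds with values here, compound 1 `C=CC[C@H]1C[C@]2([C@@H](C)Cc3ccc(OC)c(OC)c3)OCOC2=CC1=O` is one of two compounds measured in a functional assay on NCI-H460 cells (Homo sapiens) for antiproliferative activity, with a stated time of 72 h; a lower number here means a stronger inhibitor, a higher number a weaker inhibitor. In this assay compound 1 gives 260 nM, the lowest of the two numbers. Compound 2 `C=CC[C@H]1C[C@]2([C@@H](C)Cc3ccc(OC)c(C(=O)NC)c3)OCOC2=CC1=O` differs from it by a methylcarbamoyl in place of methoxy on an aromatic carbon, and in this assay compound 2 gives 1100 nM; that change gives a 4.2-fold higher number from compound 1 to compound 2 (0.63 log units; beyond the scatter). Compound 3 `C=CC[C@H]1C[C@]2([C@@H](C)Cc3cc(OC)c(OC)cc3F)OCOC2=CC1=O` differs from compound 1 in one place: fluoro in place of hydrogen on an aromatic carbon. Within the data shown here, no measured step concerns a fluoro substituent; the only step at hand, from compound 1 to compound 2, replaces one of the methoxy groups rather than adding a substituent to the ring, so it bears only loosely on this change. Both methoxy groups of compound 1 are kept in compound 3. The step is therefore expected to be small, a 1.2-fold higher number from compound 1 to compound 3 (0.06 log units; within the scatter), with no direction beyond the scatter. Compound 3 is estimated at 300 nM, within 120 nM to 800 nM.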

Compound 3, half-maximal inhibitory concentration: 120 nM
Compound 3: middle estimate off by 2.5-fold (0.40 log units), on the high side, and the stated range covers the measured number.
By their numbers in this assay, from the lowest: compound 3; then compound 1; then compound 2.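

In this assay, a substituent added to the aryl ring with both methoxy groups kept is not a neutral change: fluoro in place of hydrogen gives a step beyond the scatter (a 2.2-fold lower number from compound 1 to compound 3 (0.34 log units; beyond the scatter)). This carbon, ortho to a large group, meta to a methoxy group and para to a methoxy group, therefore accepts a fluoro, and the number moves the opposite way from the replacement of methoxy by methylcarbamoyl (a 4.2-fold higher number from compound 1 to compound 2 (0.63 log units; beyond the scatter)). No measurement at hand accounts for the effect of this single fluorine.

The compounds shown leave open whether the effect is particular to fluoro or would also appear with chloro or a methyl group on the same carbon. They also leave open what an amine or a hydroxy group would do there.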